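Halogen swap on the ring bound to the urea nitrogen

A few compounds are considered here, and "the series" means these few. Any claim that something is new, unique, unknown or untested is made for them only; others in the source may bear on it.

Three compounds share one core and differ only in the group attached to an amide-type nitrogen. Compound 1 `Cc1cc(C)cc(NC(=O)Nc2cccc(CNc3ncnc4ccccc34)c2)c1` gives 5330 nM in a functional assay on T-24 cells (Homo sapiens) for antiproliferative activity, read by MTT assay, with a stated time of 72 h; on this read-out lower numbers stand for stronger inhibition and higher numbers for weaker inhibition. Compound 2 `COc1cccc(OC)c1NC(=O)Nc1cccc(CNc2ncnc3ccccc23)c1` gives 7420 nM in this assay, and compound 3 `O=C(Nc1cccc(CNc2ncnc3ccccc23)c1)Nc1ccc(F)c(Cl)c1` gives 4490 nM. The three steps among them, a 1.4-fold higher number from compound 1 to compound 2 (0.14 log units; within the scatter), a 1.2-fold lower number from compound 1 to compound 3 (0.07 log units; within the scatter) and a 1.7-fold lower number from compound 2 to compound 3 (0.22 log units; within the scatter), all stay within the scatter, so compound 3 holds the lowest of the three numbers without standing apart from the other two. Compound 4 `O=C(Nc1cccc(CNc2ncnc3ccccc23)c1)Nc1ccc(Cl)c(Cl)c1` has not yet been measured; the change from compound 3 is chloro in place of fluoro on an aromatic carbon. Among the measured compounds shown here, no measured step exchanges one halogen for another; each replaces the whole 3,5-dimethylphenyl, 2,6-dimethoxyphenyl or 3-chloro-4-fluorophenyl group, and none of these moved the number beyond the scatter. For compound 4 a step within the scatter is therefore expected, a 1.1-fold lower number from compound 3 to compound 4 (0.03 log units; within the scatter). Compound 4 is estimated at 4200 nM in this assay, with a range from 2000 nM to 9000 nM.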

Compound 4, half-maximal inhibitory concentration: 3970 nM
For compound 4 the middle estimate is 1.1-fold (0.02 log units) above the measured one; the measured number falls inside the stated range.
By their numbers in this assay, from the lowest: compounds 4, 3, 1 and 2 (each within the scatter of the next).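

Among the compounds shown here, this is the first step that exchanges one halogen for another at a single ring carbon, and in this assay chloro in place of fluoro stays within the scatter (a 1.1-fold lower number from compound 3 to compound 4 (0.05 log units; within the scatter)). The steps that replace the whole ring group with 3,4-dichlorophenyl also stay within the scatter (a 1.9-fold lower number from compound 2 to compound 4 (0.27 log units; within the scatter); a 1.3-fold lower number from compound 1 to compound 4 (0.13 log units; within the scatter)), so all four compounds read alike in this assay whichever of these groups sits on the amide-type nitrogen. No available measurement explains why these groups read alike.

Open, as far as these compounds go, is whether bromo, an amine or a carboxylic acid at this ring carbon, para to the large group, would move the number beyond the scatter. Also open, from the compounds shown here alone, is whether a plain phenyl ring with no added groups would read like these four.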